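A few compounds are considered here, and "the series" means these few. Any claim that something is new, unique, unknown or untested is made for them only; others in the source may bear on it.

Working notes on the series. In a functional assay on HT-29 cells (Homo sapiens) for inhibition, read by MTT assay, with a stated time of 48 h (on this read-out higher numbers stand for weaker inhibition and lower numbers for stronger inhibition), compound 1 `CC1CCN(c2ccc(Nc3ncc4c(n3)N(C3CCCC3)CC(=O)N4)cc2)CC1` gives 5040 nM. Compound 2 `CCN1C(=O)CN(C2CCCC2)c2nc(Nc3ccc(N4CCN(C)CC4)cc3)ncc21` gives 10300 nM in this assay. Compound 3 `CCN1C(=O)CN(C2CCCC2)c2nc(Nc3ccc(N4CCCCC4)cc3)ncc21` reaches only the limit of this assay, > 30000 nM, so no number is known for it. Among the compounds with values here, the single step measured between compounds that differ in one place is an at least 2.9-fold higher number from compound 2 to compound 3 (0.46 log units; beyond the scatter), and no number beyond the limit exists for that change. Compound 4 `CCN1C(=O)CN(C2CCCC2)c2nc(Nc3ccc(N4CCC(C)CC4)cc3)ncc21` differs from compound 3 by methyl in place of hydrogen on a saturated ring carbon. Within the data shown here, no measured step covers this change directly. Compound 1 carries the same 4-methylpiperidin-1-yl group on a different core and gives a number in this assay rather than a limit. Because compound 3 sits at the limit of > 30000 nM in this assay, at which 1 of the 3 values shown sits, the size of any step from it cannot be read off. The step of an at least 1.5-fold lower number from compound 3 to compound 4 (0.17 log units; that floor lies within the scatter) is therefore estimated as a lowering of the number, but the uncertainty in both directions is wide. For compound 4 a value of 20000 nM is expected in this assay, with a range from 5000 nM to 60000 nM.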

Compound 4, half-maximal inhibitory concentration: 24400 nM
The estimate for compound 4 lay 1.2-fold (0.09 log units) below the measured number, and the stated range covers the measured number.
By their numbers in this assay, from the lowest: compound 1; then compound 2; then compound 4. At a limit, above all of these: compound 3.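

In this assay the step for methyl in place of hydrogen on a saturated ring carbon is an at least 1.2-fold lower number from compound 3 to compound 4 (0.08 log units; that floor lies within the scatter) and its true size cannot be read, because compound 3 is a limit and not a number: the limit of > 30000 nM in this assay, at which 1 of the 4 values shown sits. With a number now available for the 4-methylpiperidin-1-yl group on the shared core, 4-methylpiperidin-1-yl in place of 4-methylpiperazin-1-yl reads as a 2.4-fold higher number from compound 2 to compound 4 (0.37 log units; beyond the scatter) and gives this change a measured size. Within the data shown here, with 4-methylpiperidin-1-yl held constant, ethyl in place of hydrogen on the amide-type nitrogen reads as a 4.8-fold higher number from compound 1 to compound 4 (0.68 log units; beyond the scatter) and is the only measure of that change.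

Still open, as far as these compounds go, is how a hydroxyl, a primary amine or a carboxylic acid at that saturated ring carbon would compare with methyl. Also open, from the compounds shown here alone, is whether the ethyl step holds with 4-methylpiperazin-1-yl in place of 4-methylpiperidin-1-yl.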